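Benzothiophene Amide in Place of Thiazole Amide

The source may hold more compounds than are shown below. What is called first, only, known or untested is meant among the compounds shown, and "the series" means these compounds.

compound 1 `CC(=O)Nc1cccc2c(-c3cccc(NC(=O)c4ccc(C(F)(F)F)c(Cl)c4)c3)ccnc12`: 7600 nM
compound 2 `CC(=O)Nc1cccc2c(-c3cccc(NC(=O)c4nccs4)c3)ccnc12`: > 20000 nM

In a functional assay on A375P cells (Homo sapiens) for antiproliferative activity, read by MTT assay, with a stated time of 48 h (a lower number here means a stronger inhibitor, a higher number a weaker inhibitor), compound 1 gives 7600 nM. Compound 2 reaches only a limit in this assay, > 20000 nM, as the limit of > 20000 nM in this assay, at which 1 of the 2 values shown sits, records. For the measured compounds named here, the single measured step, an at least 2.6-fold higher number from compound 1 to compound 2 (0.42 log units; beyond the scatter), is the reference for what follows. Compound 3 `CC(=O)Nc1cccc2c(-c3cccc(NC(=O)c4cc5ccccc5s4)c3)ccnc12` differs from compound 2 by 1-benzothiophen-2-yl in place of 1,3-thiazol-2-yl on a carbonyl carbon. Since the entering group is a bicyclic aromatic, nearer in bulk to the 3-chloro-4-(trifluoromethyl)phenyl group of compound 1, and since an at least 2.6-fold higher number from compound 1 to compound 2 (0.42 log units; beyond the scatter) went the other way, a partial recovery is expected. Compound 3 is thus estimated at 10000 nM, between 3000 nM and 40000 nM, an expected step of an at least 2.0-fold lower number from compound 2 to compound 3 (0.30 log units; that floor lies within the scatter).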

Compound 3, half-maximal inhibitory concentration: 9100 nM
Estimate against measurement, compound 3: 1.1-fold (0.04 log units) above; low and high end bracket the measured number.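

In this assay, on a carbonyl carbon whose other neighbour is the amide-type nitrogen, 1-benzothiophen-2-yl in place of 1,3-thiazol-2-yl gives an at least 2.1-fold lower number from compound 2 to compound 3 (0.34 log units; beyond the scatter) and shows that this position can regain what the thiazole lost. With a 1.2-fold higher number from compound 1 to compound 3 (0.08 log units; within the scatter) on exchanging 3-chloro-4-(trifluoromethyl)phenyl for 1-benzothiophen-2-yl, these two groups stand level here. The size of the gain over compound 2 is only a floor, as that compound's value is a limit: the limit of > 20000 nM in this assay, at which 1 of the 3 values shown sits.

On these data alone, whether a piperidine ring on this carbonyl carbon, or an amine or a carboxylic acid carried on the 1-benzothiophen-2-yl group, would lower the number further stays open.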